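Notes on the ring-nitrogen substituent, compound 1 to compound 3

A few compounds are considered here, and "the series" means these few. Any claim that something is new, unique, unknown or untested is made for them only; others in the source may bear on it.

Measured so far in an assay on HEK-293T cells for inhibition of Bile acid receptor (Homo sapiens), read by a beta-lactamase reporter, with a stated time of 16 h; a lower number here means a stronger inhibitor, a higher number a weaker inhibitor:
- compound 1 `Cc1ccc(-c2nn(C(C)C)cc2C(=O)Nc2ccc(C)c(S(=O)(=O)N3CCOCC3)c2)cc1` gives 1690 nM
- compound 2 `Cc1ccc(NC(=O)c2cn(C(C)C)nc2-c2ccc(C(F)(F)F)cc2)cc1S(=O)(=O)N1CCOCC1` gives 1950 nM

Compound 1 holds the lower of the two numbers, though the step of a 1.2-fold higher number from compound 1 to compound 2 (0.06 log units; within the scatter) is within the scatter, so the two compounds are not separated in this assay.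

Compound 3 `Cc1ccc(-c2nn(-c3ccccc3)cc2C(=O)Nc2ccc(C)c(S(=O)(=O)N3CCOCC3)c2)cc1` has not yet been measured. It differs from compound 1 in one place: phenyl in place of isopropyl on an aromatic nitrogen.

Among the measured compounds shown here, the only measured step, a 1.2-fold higher number from compound 1 to compound 2 (0.06 log units; within the scatter), concerns a trifluoromethyl in place of a methyl on an aromatic carbon, not the group on the aromatic nitrogen, and it was within the scatter. It therefore gives no direct guide to the change in compound 3. With nothing on record for the ring-nitrogen substituent, the working expectation is a number close to that of compound 1, with a wide margin on either side.

For compound 3 the estimated result in this assay is 2000 nM, with a range of 600 nM to 7000 nM. This estimate amounts to an expected step of a 1.2-fold higher number from compound 1 to compound 3 (0.07 log units; within the scatter).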

Compound 3, half-maximal inhibitory concentration: 2620 nM
Estimate against measurement, compound 3: 1.3-fold (0.12 log units) below; low and high end bracket the measured number.
By their numbers in this assay, from the lowest: compounds 1, 2 and 3 (each within the scatter of the next).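

Notes on the ring-nitrogen substituent after compound 3

In this assay, among the compounds shown here, phenyl in place of isopropyl on the aromatic nitrogen gives a 1.6-fold higher number from compound 1 to compound 3 (0.19 log units; within the scatter), the first reading at this position, and it does not separate the two groups. A group of 6 heavy atoms with a six-membered aromatic ring thus stands where a group of 3 heavy atoms with no ring stood, without a step beyond the scatter, so a ring on this nitrogen is compatible with a result in the same range as compound 1. Nothing on record accounts for the size of this step or says what the position contributes to the result.

Open, going by these compounds, is whether the position stays this flat for a group of a different kind, such as a methyl, a longer chain ending in an amine or a carboxylic acid, or a phenyl carrying a substituent of its own. Also open, on these data alone, is whether trifluoromethyl in place of methyl on the aromatic carbon would again leave the number within the scatter when phenyl sits on the aromatic nitrogen.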